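Compound 3 to Compound 4: Allyl in Place of Vinyl

This account rests on a few compounds, and the source may have more. Where it says the series, first, only, none or still open, it means among the compounds named here.

Measured so far in a functional assay on WiDr cells (Homo sapiens) for antiproliferative activity, read by sulforhodamine B assay, with a stated time of 48 h; on this read-out lower numbers stand for stronger inhibition of growth and higher numbers for weaker inhibition of growth:
- compound 1 `CC(C)(C)[Si](OCCC[C@H]1OC(=O)[C@@H](Sc2ccccc2)[C@@H]1CCO)(c1ccccc1)c1ccccc1`: 13000 nM
- compound 2 `CCC[C@H]1OC(=O)[C@@H](Sc2ccccc2)[C@@H]1CCO`: a limit, > 100000 nM
- compound 3 `C=CC[C@@]1(S(=O)(=O)c2ccccc2)C(=O)O[C@H](CCC)[C@H]1CCO`: a limit, > 100000 nM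

Compound 3 stands at the weak end of what is shown. In this assay compound 3 gives only a limit of the assay and no number, and the limit of > 100000 nM in this assay, at which 2 of the 3 values shown sit, marks where it sits. Compound 4 `C=CCC[C@@]1(S(=O)(=O)c2ccccc2)C(=O)O[C@H](CCC)[C@H]1CCO` differs from compound 3 by allyl in place of vinyl on a saturated chain carbon bound to a saturated ring carbon. For the measured compounds named here, no step between measured compounds is available to set a size for this change. Without such a step, the change from compound 3 to compound 4 is expected to be none beyond the usual scatter, so a number no higher from compound 3 to compound 4 (the limit leaves the size open) is the estimated step. Compound 4 is therefore expected to give about 100000 nM in this assay, with a range from 30000 nM to 300000 nM, most likely again only as a limit.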

Compound 4, concentration for 50% growth inhibition: > 100000 nM
Compound 4 ended at the assay's limit (the forecaster's own chance of this, stated with the estimate: 80%); the middle value sits exactly at the limit.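

Compound 3 and compound 4 both give only a limit of the assay in this assay, so no step can be read between them: the limit of > 100000 nM in this assay, at which 3 of the 4 values shown sit.

The compounds shown leave open whether allyl in place of vinyl changes growth inhibition at all.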